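This account rests on a few compounds, and the source may have more. Where it says the series, first, only, none or still open, it means among the compounds named here.

Measured in a functional assay on DLD-1 cells (Homo sapiens) for cytotoxicity, with a stated time of 48 h (on this read-out lower numbers stand for stronger inhibition and higher numbers for weaker inhibition), each value a limit:
- compound 1 `CC(=O)Oc1ccc2oc(/C=C/[S+](C)[O-])cc(=O)c2c1`: > 10000 nM
- compound 2 `C[S+]([O-])/C=C/c1cc(=O)c2cc(C#N)ccc2o1`: > 10000 nM

Compound 2 gives only a limit, > 10000 nM. Among the measured compounds shown here, the series so far offers no number: the limit of > 10000 nM in this assay, at which 2 of the 2 values shown sit. Compound 3 `CCC(=O)Oc1ccc2oc(/C=C/[S+](C)[O-])cc(=O)c2c1` carries propanoyloxy in place of cyano on an aromatic carbon. For the measured compounds named here, the one measured step bearing on this, a step that the two limits leave unreadable from compound 1 to compound 2, has no readable size to carry over. No step beyond the scatter is therefore expected in this assay, and another limit is the likely report. The expected step is a step that the limit leaves unreadable from compound 2 to compound 3. For compound 3 the estimate is 12000 nM, with an expected range of 6000 nM to 30000 nM.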

Compound 3, half-maximal inhibitory concentration: 9000 nM
Compound 3: middle estimate off by 1.3-fold (0.12 log units), on the high side; the range from low to high includes it.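

Compound 3, at 9000 nM in this assay, gives the series its first actual number, so this aromatic position can carry a group with a readable value. Yet the change from cyano to propanoyloxy is an at least 1.1-fold lower number from compound 2 to compound 3 (0.04 log units; that floor lies within the scatter), and the added methyl on the ester chain is an at least 1.1-fold lower number from compound 1 to compound 3 (0.04 log units; that floor lies within the scatter), so neither floor shows a step beyond the scatter. Most of the series still rests on a limit: the limit of > 10000 nM in this assay, at which 2 of the 3 values shown sit.

From the compounds shown here alone, how far either step really reaches stays open. Also open, going by these compounds, is whether a longer ester chain such as butanoyloxy, or an amine at this position, would give a step beyond the scatter.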